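The source may hold more compounds than are shown below. What is called first, only, known or untested is meant among the compounds shown, and "the series" means these compounds.

The measured compounds:
Compound 1 `CN(C)CCn1cnnc1-c1cc(Oc2ccc(NC(=O)N/N=C/c3ccc(O)c(Br)c3)cc2F)ccn1`: in a functional assay on U-87MG ATCC cells (Homo sapiens) for cytotoxicity, read by MTT assay, with a stated time of 72 h (a lower number here means a stronger inhibitor, a higher number a weaker inhibitor), compound 1 gives 12400 nM.
Compound 2 `CN(C)CCn1cnnc1-c1cc(Oc2ccc(NC(=O)N/N=C/c3ccc(F)cc3)cc2F)ccn1`: in this assay compound 2 gives 2310 nM.
Compound 3 `CN(C)CCn1cnnc1-c1cc(Oc2ccc(NC(=O)N/N=C/c3ccc(F)cc3F)cc2F)ccn1`: in this assay compound 3 gives 1900 nM.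

Compound 3 has the lowest number of the three, but its gap to compound 2 lies within the scatter, so those two cannot be ordered; only compound 1 stands apart, with a clearly higher number. Compound 4 `CN(C)CCn1cnnc1-c1cc(Oc2ccc(NC(=O)N/N=C/c3ccc(O)c(O)c3)cc2F)ccn1` has not yet been measured. It differs from compound 3 in one place: 3,4-dihydroxyphenyl in place of 2,4-difluorophenyl on a carbon with a double bond to nitrogen. Among the compounds with values here, two measured steps bear on this change, both of which replaced a hydroxyl-bearing ring with a fluorinated one: a 5.4-fold lower number from compound 1 to compound 2 (0.73 log units; beyond the scatter) and a 6.5-fold lower number from compound 1 to compound 3 (0.81 log units; beyond the scatter). Both steps gave lower numbers. Compound 4 brings hydroxyls back in, two of them, so the reverse is expected, a step to a higher number, a 4.7-fold higher number from compound 3 to compound 4 (0.68 log units; beyond the scatter). Within the data shown here, this expectation rests on compound 1, the one hydroxyl-bearing compound measured, which gives 12400 nM. Compound 4 is therefore estimated at 9000 nM, with a range from 3000 nM to 27000 nM.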

Compound 4, half-maximal inhibitory concentration: > 100000 nM
Compound 4: only a limit was reported (the forecaster's own chance of this, stated with the estimate: 5%); middle value at least 11-fold (1.04 log units) from the limit.
By their numbers in this assay, from the lowest: compounds 3 and 2 (each within the scatter of the next); then compound 1. At a limit, above all of these: compound 4.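

The result for compound 4 is a limit of the assay, not a number: the limit of > 100000 nM in this assay, at which 1 of the 4 values shown sits. In this assay, the change at this ring has a far larger effect than compound 1 alone suggested, with an at least 52-fold higher number from compound 3 to compound 4 (1.72 log units; beyond the scatter) and an at least 43-fold higher number from compound 2 to compound 4 (1.63 log units; beyond the scatter). The ring with two hydroxyls also separates from the ring carrying one hydroxyl and a bromine, with an at least 8.0-fold higher number from compound 1 to compound 4 (0.90 log units; beyond the scatter), so at this position, on a carbon with a double bond to nitrogen, a single swap of hydroxy for bromo is enough to move the number beyond the scatter.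

The limit leaves the true size of all three steps unknown. The compounds shown also leave open how a ring with a single hydroxyl and no bromine, or one with methoxy groups or an amine in place of the hydroxyls, would behave here.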